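Adding a Third Methoxy to the Chalcone Aryl Ring

A few compounds are considered here, and "the series" means these few. Any claim that something is new, unique, unknown or untested is made for them only; others in the source may bear on it.

The measured compounds are:
compound 1, `COc1ccc(-c2cc(/C=C/C(=O)c3cc(OC)c(OC)c(OC)c3)[nH]n2)cc1OC`, 85%;
compound 2, `COc1ccc(C(=O)/C=C/c2cc(-c3cc(OC)c(OC)c(OC)c3)n[nH]2)cc1`, 90%;
compound 3, `COc1ccc(C(=O)/C=C/c2cc(-c3cc(OC)c(OC)c(OC)c3)n[nH]2)cc1OC`, 79%.

All three were tested in a functional assay on RPMI-8226 cells (Homo sapiens) for cytotoxicity, read by sulforhodamine B assay, with a stated time of 48 h, tested at 0.1 uM; a higher number here means a weaker effect of the compound at the concentration tested, a lower number a stronger effect. Compound 3 shows the lowest of the three numbers, but compound 1 is within the usual scatter of it, so no order between those two can be drawn; only compound 2 stands beyond the scatter, with a number 11 percentage points lower from compound 2 to compound 3 (beyond the scatter).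

The next compound, compound 4, `COc1cc(C(=O)/C=C/c2cc(-c3cc(OC)c(OC)c(OC)c3)n[nH]2)cc(OC)c1OC`, is not yet measured. It differs from compound 3 by methoxy in place of hydrogen on an aromatic carbon, placed ortho to a methoxy group and meta to a methoxy group on the six-membered aromatic ring of carbon only.

For the measured compounds named here, the single step that bears on this change is the same kind of change, a methoxy in place of hydrogen on that ring, which gave a number 11 percentage points lower from compound 2 to compound 3 (beyond the scatter), a modest lowering. A further methoxy may continue in that direction, but one step is a thin basis, and the measured values are all high, so a small lowering or none beyond the scatter is plausible.

Compound 4 is therefore expected at 72%, between 55% and 88%, meaning an estimated a number 7 percentage points lower from compound 3 to compound 4 (within the scatter).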

Compound 4, a percentage reported as activity, at one concentration (the size of the read-out at that concentration, not a potency): 83%
Compound 4: middle estimate off by 11 percentage points, on the low side; the range from low to high includes it.
By their numbers in this assay, from the lowest: compounds 3, 4, 1 and 2 (each within the scatter of the next, the first and the last beyond it).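

In this assay, a further methoxy in place of hydrogen on the six-membered aromatic ring of carbon only does not repeat the lowering seen earlier on that ring: a number 4 percentage points higher from compound 3 to compound 4 (within the scatter). At this place, ortho to a methoxy group and meta to a methoxy group, the added group therefore gives no difference that can be told from the usual scatter, so the earlier step cannot be read as a trend that continues with each added methoxy. The same kind of change on the second core also stays within the scatter, a number 2 percentage points lower from compound 1 to compound 4 (within the scatter), and the two steps cannot be told apart, so the compounds give no sign that the size of this step depends on the core: the same change on two cores in this assay, a number 11 percentage points lower (beyond the scatter) from compound 2 to compound 3 and a number 2 percentage points lower (within the scatter) from compound 1 to compound 4, 9 percentage points apart, within the scatter of two such steps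

Going by these compounds, what stays open is whether a different group at this place, such as a hydroxyl, an amine or a longer alkoxy chain, would move the number beyond the scatter of compound 3. With only one concentration in the data, these compounds also leave open how their potencies compare.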